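Swapping drawn double-bond geometry in a chalcone-like ester

This account rests on a few compounds, and the source may have more. Where it says the series, first, only, none or still open, it means among the compounds named here.

Three measured compounds share one core. Compound 1 `CC(=O)OC/C(=C\c1ccccc1Br)C(=O)c1ccccc1` gives 17000 nM in a functional assay on T47D cells (Homo sapiens) for inhibition, read by sulforhodamine B assay, with a stated time of 48 h; on this read-out higher numbers stand for weaker inhibition of growth and lower numbers for stronger inhibition of growth. Compound 2 `CC(=O)OC/C(=C\c1ccccc1[N+](=O)[O-])C(=O)c1ccccc1` gives 21000 nM in this assay, and compound 3 `O=C(OC/C(=C\c1ccccc1[N+](=O)[O-])C(=O)c1ccccc1)c1ccccc1` gives 16000 nM in this assay. The step of a 1.2-fold higher number from compound 1 to compound 2 (0.09 log units; within the scatter) and the step of a 1.3-fold lower number from compound 2 to compound 3 (0.12 log units; within the scatter) both stay within the scatter, so compound 2 sits in the same narrow band as compound 1 and compound 3, with no separation between them that the assay can resolve.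

Compound 4 `CC(=O)OC/C(=C/c1ccccc1[N+](=O)[O-])C(=O)c1ccccc1` differs from compound 2 only in drawn configuration: the two compounds have the same atoms and bonds and differ only in configuration as drawn: 1 of 1 stereo elements differ; a double bond is drawn E in compound 2 and Z in compound 4. Among the compounds with values here, none of the measured steps concerns such a change; the two measured steps exchanged a bromo for a nitro on an aromatic carbon and a methyl for a phenyl on a carbonyl carbon, and each stayed within the scatter. Within the data shown here, with no comparable precedent, the size of a 1.1-fold lower number from compound 2 to compound 4 (0.02 log units; within the scatter) is expected to be small in either direction, with wide uncertainty. Compound 4 is therefore estimated at 20000 nM, within a range from 6000 nM to 65000 nM.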

Compound 4, concentration for 50% growth inhibition: 52000 nM
Compound 4: middle estimate off by 2.6-fold (0.41 log units), on the low side, and the stated range covers the measured number.
By their numbers in this assay, from the lowest: compounds 3, 1 and 2 (each within the scatter of the next); then compound 4.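

Turning the double bond from E to Z gives a 2.5-fold higher number from compound 2 to compound 4 (0.39 log units; beyond the scatter), the first step in this set that lies beyond the scatter in this assay, and it points to weaker inhibition of growth. The exchanges of bromo for nitro and of methyl for phenyl both stayed within the scatter, so in this series the geometry at this double bond has shown an effect that neither of those exchanges showed. The step is modest, yet it can be tied to the double bond alone, because nothing else changes: the fact that compounds 2 and 4 differ only in the configuration as drawn

As far as these compounds go, whether the same switch would shift compound 1 or compound 3 in the same direction, and by a similar amount, remains open. Also open, from the compounds shown here alone, is how an amine or a carboxylic acid in place of the nitro would behave in either geometry.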